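The source may hold more compounds than are shown below. What is called first, only, known or untested is meant among the compounds shown, and "the series" means these compounds.

Working notes on the series. Compound 1 `COc1ccccc1OC(C)(C)C1OCC(C/C=C\CCC(=O)O)C(c2cccnc2)O1` carries a methoxy on the aromatic ring, and compound 2 `CC(C)(Oc1ccccc1O)C1OCC(C/C=C\CCC(=O)O)C(c2cccnc2)O1` carries a hydroxy in that place; otherwise the two share one core. In an assay for inhibition of prostacyclin synthase (Homo sapiens), using microsomes (a higher number here means a weaker inhibitor, a lower number a stronger inhibitor), compound 1 gives 51000 nM. Compound 2 is reported only as > 100000 nM, which is a limit of the assay and not a number. Going by the values given here, compound 2 therefore stands at the limit of > 100000 nM in this assay, at which 1 of the 2 values shown sits, and of the two measured values it is the one without a number. The only measured step is an at least 1.9-fold higher number from compound 1 to compound 2 (0.29 log units; that floor lies within the scatter), whose floor lies within the scatter, so the move from methoxy to hydroxy is not shown to change the number beyond the usual spread.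

Compound 3 `CC(C)(Oc1ccccc1Br)C1OCC(C/C=C\CCC(=O)O)C(c2cccnc2)O1` differs from compound 2 by bromo in place of hydroxy on an aromatic carbon. Among the compounds with values here, no measured step involves a bromo group, and the one measured step ends at a limit, so the expected step of an at least 1.2-fold lower number from compound 2 to compound 3 (0.09 log units; that floor lies within the scatter) is estimated on thin ground and may be none beyond the scatter. For compound 3 in this assay the estimate is 80000 nM, with a range from 25000 nM to 300000 nM, and a fair chance that only a limit is reported.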

Compound 3, half-maximal inhibitory concentration: 7000 nM
For compound 3 the middle estimate is 11-fold (1.06 log units) above the measured one, outside the stated range (below it).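

Bromo in place of hydroxy gives an at least 14-fold lower number from compound 2 to compound 3 (1.15 log units; beyond the scatter), and bromo in place of methoxy gives a 7.3-fold lower number from compound 1 to compound 3 (0.86 log units; beyond the scatter), so in this assay the group on this aromatic carbon, ortho to a large group, can move the number beyond the scatter, which the step from methoxy to hydroxy did not show. With both of its steps beyond the scatter, compound 3 is the strongest inhibitor of the three shown, although its value remains modest on the scale of the assay's numbers here. Compound 2 stands at a limit and not at a number, so the step that ends there gives a floor and not a full size: the limit of > 100000 nM in this assay, at which 1 of the 3 values shown sits.

Bromo is the only halogen among these compounds, so it remains open whether chloro or fluoro, or a non-halogen group such as methyl or an amine, would give a similar step on this carbon. As far as these compounds go, it is also open whether bromo would give the same step on another carbon of the aromatic ring.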